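Replacing benzyl with cyclohexyl on the oxime oxygen

The source may hold more compounds than are shown below. What is called first, only, known or untested is meant among the compounds shown, and "the series" means these compounds.

Compound 1 `N/N=C/c1c(N)ncnc1Oc1ccc(NC(=O)C2(C(=O)Nc3ccc(F)cc3)CC2)cc1F` gives 2.25 in a physicochemical assay for lipophilicity, using the shake flask method; a higher number here means a more lipophilic compound, a lower number a more polar compound.
Compound 2 `Nc1ncnc(Oc2ccc(NC(=O)C3(C(=O)Nc4ccc(F)cc4)CC3)cc2F)c1/C=N/OCc1ccccc1` gives 4.45 in this assay.

Among the measured compounds shown here, compound 2 stands highest of the two numbers; the one measured step, a number 2.20 log units higher from compound 1 to compound 2 (beyond the scatter), lies beyond the scatter. Compound 3 `Nc1ncnc(Oc2ccc(NC(=O)C3(C(=O)Nc4ccc(F)cc4)CC3)cc2F)c1/C=N/OC1CCCCC1` differs from compound 2 by cyclohexyl in place of benzyl on an oxygen. For the measured compounds named here, no measured step shows this exact swap; the step from compound 1 to compound 2 concerns a different group and bears only loosely. The expected step is small and upward, a number 0.55 log units higher from compound 2 to compound 3 (beyond the scatter). Compound 3 is therefore estimated at 5, ranging from 4.4 to 5.6.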

Compound 3, partition coefficient: 4.69
Compound 3: the middle estimate sits 0.31 log units above what was measured; the range from low to high includes it.
By their numbers in this assay, from the lowest: compound 1; then compounds 2 and 3 (each within the scatter of the next).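

In this assay, cyclohexyl in place of benzyl on this oxygen gives a number 0.24 log units higher from compound 2 to compound 3 (within the scatter), so an aromatic and a non-aromatic ring cannot be told apart here. Measured against amino, cyclohexyloxy gives a number 2.44 log units higher from compound 1 to compound 3 (beyond the scatter), which shows that the large step seen with benzyloxy is not confined to that one group. Nothing measured here explains either step. Still open, going by these compounds, is whether an amine or a carboxylic acid on this oxygen, or a longer carbon chain there, would read close to compound 2 and compound 3 or close to compound 1.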